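Growth inhibition series: phenoxy to dimethylamino exchange

This account rests on a few compounds, and the source may have more. Where it says the series, first, only, none or still open, it means among the compounds named here.

Measured so far:
compound 1 `COc1cc(C)cc(-c2c(-c3ccnc(-c4ccc(C(C)=O)cc4)c3)cnn2CC#N)c1` — > 100000 nM, a limit
compound 2 `COc1cc(C)cc(-c2nn(CC#N)cc2-c2ccc(-c3cccc(C(C)=O)c3)nc2)c1` — > 100000 nM, a limit
compound 3 `Cc1cc(O)cc(-c2nn(CC#N)cc2-c2ccnc(-c3ccc(Oc4ccccc4)cc3)c2)c1` — 4020 nM

Among the measured compounds shown here, in a functional assay on SN12C cells (Homo sapiens) for inhibition, read by sulforhodamine B assay, with a stated time of 48 h (a lower number here means a stronger inhibitor of growth, a higher number a weaker inhibitor of growth), compound 3 gives 4020 nM, the only actual number in the set. For the measured compounds named here, the rest of the series is defined by the limit of > 100000 nM in this assay, at which 2 of the 3 values shown sit, so no measured step between compounds exists to calibrate against.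

Compound 4 `Cc1cc(O)cc(-c2nn(CC#N)cc2-c2ccnc(-c3ccc(N(C)C)cc3)c2)c1` carries dimethylamino in place of phenoxy on an aromatic carbon. With no comparable step shown, the expected change is modest: a step in this assay from compound 3 to compound 4 of a 1.5-fold higher number from compound 3 to compound 4 (0.17 log units; within the scatter), not clearly beyond the scatter, is the working expectation. Compound 4 is therefore estimated at 6000 nM, with a range of 2000 nM to 20000 nM.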

Compound 4, concentration for total growth inhibition: 30000 nM
Estimate against measurement, compound 4: 5.0-fold (0.70 log units) below; measured number above the stated range.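

Replacing phenoxy with dimethylamino, on an aromatic carbon para to a large group, is not a neutral exchange in this assay: the change gives a 7.5-fold higher number from compound 3 to compound 4 (0.87 log units; beyond the scatter). Compound 4 still gives a measured number, 30000 nM, so this exchange gives a readable value in the series. Nothing shown gives a cause for this step.

This single exchange cannot separate the loss of the aromatic ring from the entry of the dimethylamino nitrogen. From the compounds shown here alone, how a benzyloxy group or a piperidine ring at this place would read remains open.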